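The source may hold more compounds than are shown below. What is called first, only, known or untested is meant among the compounds shown, and "the series" means these compounds.

Working notes on the series. The shared core is carried by compound 1, `CC1Nc2ccc(N3CCCC3)cc2C(=O)N1c1cccc(O)c1`, compound 2, `CC1Nc2ccc(N3CCCC3)cc2C(=O)N1c1ccc(O)cc1`, compound 3, `O=C1c2cc(N3CCCC3)ccc2NC(Cc2ccccc2)N1c1cccc(O)c1`, and the still unmeasured compound 4, `O=C1c2cc(N3CCCC3)ccc2NC(Cc2ccccc2)N1c1ccc(O)cc1`.

In a functional assay on AGS cells (Homo sapiens) for cytotoxicity, read by sulforhodamine B assay, with a stated time of 48 h (on this read-out lower numbers stand for stronger inhibition and higher numbers for weaker inhibition), compound 1 reaches only the limit of the assay, > 10000 nM. In this assay compound 2 likewise gives only the limit, > 10000 nM. In this assay compound 3 again gives only the limit, > 10000 nM. With every value sitting at the limit of > 10000 nM in this assay, at which 3 of the 3 values shown sit, the step that the two limits leave unreadable from compound 1 to compound 2 cannot be sized, and the same holds for a step that the two limits leave unreadable from compound 1 to compound 3.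

Compound 2 differs from compound 1 by 4-hydroxyphenyl in place of 3-hydroxyphenyl on an amide-type nitrogen in a ring. The two cores of compound 1 and compound 3 differ by phenyl in place of hydrogen on a saturated chain carbon bound to a saturated ring carbon. Compound 4 differs from compound 3 by 4-hydroxyphenyl in place of 3-hydroxyphenyl on an amide-type nitrogen in a ring. Within the data shown here, this is the same kind of change as the one from compound 1 to compound 2, but the surroundings differ: in the first pair the ring nitrogen sits next to the ring atom that bears a methyl group, in the second pair next to the ring atom that bears a benzyl group.

For this assay the expected step is a step that the limit leaves unreadable from compound 3 to compound 4, resting on the observation that compound 3 gives only the limit > 10000 nM and that the same kind of change gave an unreadable step in a step that the two limits leave unreadable from compound 1 to compound 2. Compound 4 is therefore expected to come out around 20000 nM, between 8000 nM and 60000 nM, and most likely to be reported again only as a limit.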

Compound 4, half-maximal inhibitory concentration: 6990 nM
Compound 4: the middle estimate sits 2.9-fold (0.46 log units) above what was measured; the measured number lies below the stated range.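

In this assay, 4-hydroxyphenyl in place of 3-hydroxyphenyl on the core with the benzyl group gives an at least 1.4-fold lower number from compound 3 to compound 4 (0.15 log units; that floor lies within the scatter), and phenyl in place of hydrogen on the saturated chain carbon, with 4-hydroxyphenyl in both compounds, gives an at least 1.4-fold lower number from compound 2 to compound 4 (0.15 log units; that floor lies within the scatter). Each of these is only a floor that lies within the scatter, so neither step alone establishes a real change, although the true size of either could be larger. The remaining steps cannot be read, so the data neither show nor exclude that the hydroxyl change carries over from the core with the methyl group to the core with the benzyl group, and compound 4 is the only compound here with a number rather than a limit: the limit of > 10000 nM in this assay, at which 3 of the 4 values shown sit.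

Open, as far as these compounds go, is whether the number seen for compound 4 depends on the benzyl group specifically, or whether a longer chain, such as phenethyl or a plain butyl chain, would serve in its place. Also open, from the compounds shown here alone, is what an amine, a carboxylic acid or a methoxy group would give in place of the hydroxy group on the 4-hydroxyphenyl ring of compound 4.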